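This account rests on a few compounds, and the source may have more. Where it says the series, first, only, none or still open, it means among the compounds named here.

Measured compounds:
- compound 1, `O=C(CCCCC1CCSS1)NCc1cn(CCCOc2ccc3ccc(=O)oc3c2)nn1`, gives 39.2%
- compound 2, `Cc1cc(=O)oc2cc(OCCCn3cc(CNC(=O)CCCCC4CCSS4)nn3)ccc12`, gives 64.6%
- compound 3, `O=C(CCCCC1CCSS1)NCc1cn(CCCCCOc2ccc3ccc(=O)oc3c2)nn1`, gives 64.5%

All three numbers come from a functional assay on PC-12 cells (Rattus norvegicus) for cytotoxicity, read by MTT assay, with stated times of 3 h and 2 h, tested at 5 uM; on this read-out lower numbers stand for a weaker effect and higher numbers for a stronger effect at the one concentration tested. Compound 1 and compound 2 share one core and differ in a single spot: methyl in place of hydrogen on an aromatic carbon. That change produced a number 25.4 percentage points higher from compound 1 to compound 2 (beyond the scatter), so on this read-out the methyl went along with a clearly stronger effect in this assay. Compound 3 stands on a different core from compound 1; how the two cores differ is not broken down here. What can be said is that compound 3 and compound 2 give numbers within the scatter of each other, while compound 3 and compound 1 lie clearly apart.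

Compound 4, `Cc1cc(=O)oc2cc(OCCCCCn3cc(CNC(=O)CCCCC4CCSS4)nn3)ccc12`, has not yet been measured. It relates to compound 3 exactly as compound 2 relates to compound 1: methyl in place of hydrogen on an aromatic carbon. Both place descriptions read the same, so this is the same change on the other core. Given the step from compound 1 to compound 2, a rise is expected here as well, though compound 3 already starts near the level of compound 2, so a somewhat smaller step is expected, namely a number 11.5 percentage points higher from compound 3 to compound 4 (beyond the scatter). The expected value for compound 4 is therefore 76%, with the likely range running from 62% to 88%.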

Compound 4, a percentage reported as activity, at one concentration (the size of the read-out at that concentration, not a potency): 61%
The estimate for compound 4 lay 15 percentage points above the measured number, outside the stated range (below it).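

In this assay, methyl in place of hydrogen on an aromatic carbon gives a number 3.5 percentage points lower from compound 3 to compound 4 (within the scatter), so on the core of compound 3 this change has no effect that can be told apart from ordinary variation between repeated measurements. The methyl therefore does not carry over from one core to the other with the same result, and the gap between the two steps is larger than chance scatter would readily explain: the same change on two cores in this assay, a number 25.4 percentage points higher (beyond the scatter) from compound 1 to compound 2 and a number 3.5 percentage points lower (within the scatter) from compound 3 to compound 4, 28.9 percentage points apart, beyond the scatter of two such steps This shows that the outcome of this one small change depends on the core that carries it, but it does not show which feature of the cores is responsible, and two pairs of compounds give no rule for what the methyl would do on any further core.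

The compounds shown carry only hydrogen or methyl at this place, so what an ethyl group, a chlorine atom or a methoxy group would give there remains open. Also open, on these data alone, is how a longer chain, or an amine in the chain, would affect these numbers, and how any of the compounds would behave at other concentrations.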